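Adding a hydroxyl to the aminoethyl chain

The source may report more compounds than this note shows. Statements on the series, on what has been measured and on what is new or still open speak of the compounds shown alone.

Compound 2 `CC(C)c1n[nH]c2c(NCc3ccc(-c4ccccn4)cc3)nc(SCCN)nc12` is the stronger of the two compounds measured in a functional assay on HT cells (Homo sapiens) for antiproliferative activity, read by fluorescence, with a stated time of 72 h; a lower number here means a stronger inhibitor of growth, a higher number a weaker inhibitor of growth; compound 2 gives 22 nM, while compound 1 `CC(C)c1n[nH]c2c(NCc3ccc(-c4ccccn4)cc3)nc(SCC(O)C(F)(F)F)nc12` gives 690 nM. Among the measured compounds shown here, the one measured step, a 31-fold lower number from compound 1 to compound 2 (1.50 log units; beyond the scatter), shows that the amine-bearing chain is far more active than the hydroxy-trifluoroethyl chain. Compound 3 `CC(C)c1n[nH]c2c(NCc3ccc(-c4ccccn4)cc3)nc(SC[C@H](O)CN)nc12` keeps the amine and adds a hydroxyl: 2-amino-1-hydroxyethyl in place of aminomethyl on a saturated chain carbon bound to a sulfur. For the measured compounds named here, no measured pair tests a hydroxyl added beside a retained amine, so the only guide is that the amine, which drove the large gain in compound 2, is still present in compound 3. The expected step is therefore small, a 1.4-fold higher number from compound 2 to compound 3 (0.13 log units; within the scatter), within or near the scatter. Compound 3 is estimated at 30 nM in this assay, with a likely range from 8 nM to 120 nM.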

Compound 3, concentration for 50% growth inhibition: 63 nM
Beside the measured number, compound 3's estimate is 2.1-fold (0.32 log units) below it; measured number inside the range.
By their numbers in this assay, from the lowest: compound 2; then compound 3; then compound 1.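

In this assay, adding the hydroxyl while keeping the amine carries a real cost at this position: a 2.9-fold higher number from compound 2 to compound 3 (0.46 log units; beyond the scatter). The amine still counts for much when both chains carry a hydroxyl, as 2-amino-1-hydroxyethyl in place of 2,2,2-trifluoro-1-hydroxyethyl gives an 11-fold lower number from compound 1 to compound 3 (1.04 log units; beyond the scatter). No measurement at hand accounts for either step.

Compound 3 differs from compound 2 in both chain length and the hydroxyl, and these compounds cannot show which of the two matters; a 3-aminopropyl chain, which has the added carbon without the hydroxyl, would separate them. The form of 3-amino-2-hydroxypropyl with the opposite arrangement at its stereocentre would show whether that arrangement matters as well.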